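Enlarging a methyl to cyclopropylmethyl on a cinnamic acid

This account rests on a few compounds, and the source may have more. Where it says the series, first, only, none or still open, it means among the compounds named here.

The account follows compound 1 `Cc1cc(O[C@@H](C)c2c(Cl)ccc(F)c2Cl)ccc1/C=C/C(=O)O` and the not yet measured compound 4 `C[C@H](Oc1ccc(/C=C/C(=O)O)c(CC2CC2)c1)c1c(Cl)ccc(F)c1Cl`. In a physicochemical assay for lipophilicity, using the shake flask method (on this read-out lower numbers stand for lower lipophilicity and higher numbers for higher lipophilicity), compound 1 gives 3.2. Among the three compounds measured in this assay it holds the second highest number: the nearest is compound 3 `C[C@H](Oc1ccc2ncc(-c3ccn(CCC(=O)O)n3)c(C3CC3)c2c1)c1c(Cl)cccc1Cl`, which in this assay gives 2.7, a gap beyond the usual scatter; the furthest is compound 2 `C[C@H](Oc1ccc2ncc(/C=C/C(=O)O)c(C3CC3)c2c1)c1c(Cl)ccc(F)c1Cl`, which in this assay gives 4.1, also beyond the scatter. No pair among these three differs in only one place, so none of the gaps can be tied to a single change.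

Compound 4 differs from compound 1 in one place: cyclopropyl in place of hydrogen on a saturated chain carbon bound to an aromatic carbon. For the measured compounds named here, since no measured pair shows this kind of change, the expectation rests on the added ring of three carbons alone. It is expected to raise the number in this assay by a clear step, larger than the scatter, and it is estimated that the step from compound 1 to compound 4 in this assay will be a number 0.80 log units higher from compound 1 to compound 4 (beyond the scatter). Compound 4 is therefore expected to give about 4 in this assay, within a range from 3.5 to 4.5.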

Compound 4, distribution coefficient: 3.9
The estimate for compound 4 lay 0.10 log units above the measured number; the measured number falls inside the stated range.
By their numbers in this assay, from the lowest: compound 3; then compound 1; then compounds 4 and 2 (each within the scatter of the next).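

With compounds 1 and 4, the series gains its first pair that differs in one place, so a gap in this assay can now be tied to a single change: cyclopropyl in place of hydrogen on a saturated chain carbon bound to an aromatic carbon. The step is a number 0.70 log units higher from compound 1 to compound 4 (beyond the scatter), modest in size but clear of the usual scatter, which shows that this position does not leave the number untouched when methyl is enlarged to cyclopropylmethyl. Nothing in hand explains why the number moves by this amount.

This one pair speaks for a single group at a single place, and it cannot say whether an open butyl chain in place of cyclopropylmethyl would give a similar number in this assay. It also leaves open what an amine on the same saturated chain carbon would do, and whether the same change on the core of compound 2 or compound 3 would give a step of like size.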